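This account rests on a few compounds, and the source may have more. Where it says the series, first, only, none or still open, it means among the compounds named here.

Among the measured compounds shown here, compound 2 `Nc1scc(CN2CCN(C3CCCCCC3)CC2)c1C(=O)c1ccc(Cl)cc1` is one of two compounds measured in a functional assay on CHO cells with adenosine receptor A1 (Homo sapiens) as the target, read by cAMP accumulation and immunoassay, with a stated time of 6 min, tested at 0.01 uM; on this read-out lower numbers stand for a stronger effect and higher numbers for a weaker effect at the one concentration tested. Compound 2 gives 2.9%, while compound 1 `Nc1scc(CN2CCN(c3ccc(F)cc3Cl)CC2)c1C(=O)c1ccc(Cl)cc1` gives 6.1%. Compound 2 has the lower of the two numbers, but the step of a number 3.2 percentage points lower from compound 1 to compound 2 (within the scatter) is within the scatter, so the two compounds cannot be told apart on this read-out. Compound 3 `Nc1scc(CN2CCN(c3cccc4ccccc34)CC2)c1C(=O)c1ccc(Cl)cc1` has not yet been measured; it differs from compound 2 in one place: naphthalen-1-yl in place of cycloheptyl on an amine nitrogen in a ring. For the measured compounds named here, the only measured step that bears on this change is the one in which cycloheptyl replaced 2-chloro-4-fluorophenyl on an amine nitrogen in a ring, and that step was within the scatter. Putting an aromatic group back in the same place is therefore expected to give no step beyond the scatter, an estimated step of a number 2.1 percentage points higher from compound 2 to compound 3 (within the scatter). Compound 3 is expected to give 5%, with a likely range from -5% to 15%.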

Compound 3, a percentage reported as activity, at one concentration (the size of the read-out at that concentration, not a potency): 8.7%
Beside the measured number, compound 3's estimate is 3.7 percentage points below it; measured number inside the range.
By their numbers in this assay, from the lowest: compounds 2, 1 and 3 (each within the scatter of the next).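

In this assay the amine nitrogen of the six-membered ring now carries three quite different groups without the read-out separating them: a seven-membered non-aromatic ring, a substituted single aromatic ring and the two fused aromatic rings of naphthalen-1-yl. Naphthalen-1-yl in place of cycloheptyl gives one step (a number 5.8 percentage points higher from compound 2 to compound 3 (within the scatter)), and naphthalen-1-yl in place of 2-chloro-4-fluorophenyl gives another (a number 2.6 percentage points higher from compound 1 to compound 3 (within the scatter)), so neither the larger aromatic group nor the change from a non-aromatic ring shows a measurable effect here. Nothing available explains why these groups read alike.

Still open, on these data alone, is whether a group of another kind at this nitrogen, such as a carboxylic acid or a longer chain, would give a step beyond the scatter. A reading at one concentration also leaves open whether these three compounds would show a stronger or weaker effect at any other concentration.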